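The source may report more compounds than this note shows. Statements on the series, on what has been measured and on what is new or still open speak of the compounds shown alone.

Compound 1 `O=C(NCc1cc(Cl)ccc1-n1cnnn1)[C@@H]1CC=NN1C(=O)[C@H](O)c1ccccc1` and compound 3 `CC(C)(C)C[C@@H](O)C(=O)N1N=CC[C@H]1C(=O)NCc1cc(Cl)ccc1-n1cnnn1` share one core and differ in a single group: neopentyl in place of phenyl on a saturated chain carbon bound to a carbonyl carbon and an oxygen on a saturated carbon In an ADME assay on Caco-2 cells (Homo sapiens) for permeability, read by LC-MS, in the apical to basolateral direction, with a stated time of 60 min, at pH 6.5 (a lower number here means that the compound crosses the layer more slowly, a higher number that the compound crosses the layer faster), compound 1 gives 7 10^-6 cm/s and compound 3 gives 24 10^-6 cm/s, so this change brought a 3.4-fold higher number from compound 1 to compound 3 (0.54 log units; beyond the scatter). Compound 2 `O=C([C@H](O)c1ccccc1)N1CC[C@@H]2C[C@@]21C(=O)NCc1cc(Cl)ccc1-n1cnnn1` is built on a different core; the difference between the two cores is not broken down here. In this assay compound 2 gives 2.6 10^-6 cm/s, the lowest of the three numbers. Compound 4 `CC(C)(C)C[C@@H](O)C(=O)N1CC[C@@H]2C[C@@]21C(=O)NCc1cc(Cl)ccc1-n1cnnn1` arises from compound 2 by the same change: neopentyl in place of phenyl on a saturated chain carbon bound to a carbonyl carbon and an oxygen on a saturated carbon The expected step from compound 2 to compound 4 in this assay is a 3.3-fold higher number from compound 2 to compound 4 (0.51 log units; beyond the scatter), about the size of the earlier step, because the same change on the other core gave a 3.4-fold higher number from compound 1 to compound 3 (0.54 log units; beyond the scatter). On that basis compound 4 is estimated at 8.5 10^-6 cm/s, with a range from 4 10^-6 cm/s to 18 10^-6 cm/s.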

Compound 4, apparent permeability: 7.8 10^-6 cm/s
Compound 4: the middle estimate sits 1.1-fold (0.04 log units) above what was measured, and the stated range covers the measured number.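

In this assay, putting neopentyl in place of phenyl gave a 3.0-fold higher number from compound 2 to compound 4 (0.48 log units; beyond the scatter). The change carried over from one core to the other with much the same size: the same change on two cores in this assay, a 3.4-fold higher number (0.54 log units; beyond the scatter) from compound 1 to compound 3 and a 3.0-fold higher number (0.48 log units; beyond the scatter) from compound 2 to compound 4, 1.1-fold (0.06 log units) apart, within the scatter of two such steps. For the compounds shown here, this rests on only two pairs of compounds, so it shows that the step held on these two cores, but not that it would hold on any other core, and it does not explain why the number goes up.

The compounds shown leave open whether a different group in the same place, such as a longer chain or an amine, would give a step of similar size. From the compounds shown here alone, it also remains open whether a carboxylic acid there would reverse the direction of the step.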